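The compounds below may be only part of what the source reports. "The series", "measured", "known", "first", "only" and "open" are said of these compounds alone.

Measured compounds in the series:

compound 1, `CCOC(=O)C12C(=O)OCC=C1COC2c1ccccc1` — > 1000000 nM
compound 2, `CCOC(=O)C12C(=O)OCC=C1COC2c1ccc(OC)cc1` — > 1000000 nM
compound 3, `CCOC(=O)C12C(=O)OCC=C1COC2c1cc(OC)cc(OC)c1` — > 1000000 nM

All three share one core and differ only in the methoxy groups on the pendant aromatic ring. In a functional assay on QGY cells (Homo sapiens) for cytotoxicity, read by MTT assay (a lower number here means a stronger inhibitor, a higher number a weaker inhibitor), compound 1 gives no number, only a limit, > 1000000 nM. Compound 2 in this assay also gives only a limit, > 1000000 nM. Compound 3 likewise gives only a limit, > 1000000 nM. The change from compound 1 to compound 2 is methoxy in place of hydrogen on an aromatic carbon. The step it made, a step that the two limits leave unreadable from compound 1 to compound 2, cannot be read because of the limit of > 1000000 nM in this assay, at which 3 of the 3 values shown sit. The difference between the core of compound 1 and the core of compound 3 is not broken down here.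

Compound 4, `CCOC(=O)C12C(=O)OCC=C1COC2c1cc(OC)c(OC)c(OC)c1`, has not yet been measured in this assay. It differs from compound 3 by methoxy in place of hydrogen on an aromatic carbon. This is the same kind of change as that from compound 1 to compound 2, though not the same: in compound 4 the place is ortho to two methoxy groups (2 heavy atoms each) and para to a large group, whereas in compound 2 it is para to a large group only.

Because the step that the two limits leave unreadable from compound 1 to compound 2 stayed unreadable, the step from compound 3 to compound 4 is expected to be a number no higher from compound 3 to compound 4 (the limit leaves the size open), with no indication that this assay would now register a number. For compound 4 the estimate is 1000000 nM, with a range from 300000 nM to 3000000 nM, and most probably again only a limit will be reported.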

Compound 4, half-maximal inhibitory concentration: > 1000000 nM
Compound 4: only a limit was reported; the forecaster's own chance of this, stated with the estimate: 85%; the middle value sits exactly at the limit.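

In this assay compound 4 gives > 1000000 nM as a limit and not a number. Among the compounds shown here, the step from compound 3 to compound 4 therefore cannot be read, and no new step follows from this result: the limit of > 1000000 nM in this assay, at which 4 of the 4 values shown sit. The compounds shown leave open whether methoxy groups on the pendant aromatic ring change the activity of the shared core at all, and what number any of these compounds would give in this assay.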